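This account rests on a few compounds, and the source may have more. Where it says the series, first, only, none or still open, it means among the compounds named here.

Three compounds share one core and differ only in the group attached to one aromatic carbon. Compound 1 `CC1CCN(C2CCN(S(=O)(=O)c3cccc(N)c3)CC2)CC1` carries an amino group there, and in a functional assay on DLD-1 cells (Homo sapiens) for antiproliferative activity, read by CellTiter-Glo, with a stated time of 72 h (on this read-out lower numbers stand for stronger inhibition and higher numbers for weaker inhibition), compound 1 gives 3400 nM. Compound 2 `Cc1cccc(S(=O)(=O)N2CCC(N3CCC(C)CC3)CC2)c1` carries a methyl instead; in this assay compound 2 gives 25 nM, the step being a 140-fold lower number from compound 1 to compound 2 (2.13 log units; beyond the scatter). Compound 3 `CC1CCN(C2CCN(S(=O)(=O)c3cccc(-c4ccc(F)cc4)c3)CC2)CC1` carries a 4-fluorophenyl; in this assay compound 3 gives 12 nM, reached by a 280-fold lower number from compound 1 to compound 3 (2.45 log units; beyond the scatter) and by a 2.1-fold lower number from compound 2 to compound 3 (0.32 log units; beyond the scatter). Compound 3 thus stands lowest of the three numbers, the strongest inhibition measured here.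

Compound 4 `CC1CCN(C2CCN(S(=O)(=O)c3cccc(-c4ccccc4C(F)(F)F)c3)CC2)CC1` differs from compound 3 by 2-(trifluoromethyl)phenyl in place of 4-fluorophenyl on an aromatic carbon. Going by the values given here, of the measured steps, only the one from compound 2 to compound 3 bears on this change, since it was the one that introduced an aromatic ring at this carbon, and it was modest. Swapping one aromatic ring for another is expected to move the number less than that. The expected step from compound 3 to compound 4 is a 1.7-fold higher number from compound 3 to compound 4 (0.22 log units; within the scatter), within the scatter. Compound 4 is therefore expected to give about 20 nM in this assay, with a range from 5 nM to 80 nM.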

Compound 4, half-maximal inhibitory concentration: 10 nM
The estimate for compound 4 lay 2.0-fold (0.30 log units) above the measured number, and the stated range covers the measured number.
By their numbers in this assay, from the lowest: compounds 4 and 3 (each within the scatter of the next); then compound 2; then compound 1.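

At this aromatic carbon, the ring can carry quite different substituents without a readable change in this assay: replacing 4-fluorophenyl with 2-(trifluoromethyl)phenyl gives a 1.2-fold lower number from compound 3 to compound 4 (0.08 log units; within the scatter). The new group also improves modestly on methyl, with a 2.5-fold lower number from compound 2 to compound 4 (0.40 log units; beyond the scatter), and far more on amino, with a 340-fold lower number from compound 1 to compound 4 (2.53 log units; beyond the scatter), so amino remains the one clear outlier among the four groups at this position. No measured evidence here explains why the two substituted phenyl groups read alike.

From the compounds shown here alone, it remains open whether a carboxylic acid, a pyridine ring or a longer alkyl chain at this carbon would keep the number as low as these phenyl groups do. It is also unknown whether a dimethylamino or acetamide group would give a number as high as that of amino.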